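Triazole aryl swap: thiophene in place of tolyl

The source may report more compounds than this note shows. Statements on the series, on what has been measured and on what is new or still open speak of the compounds shown alone.

Within the data shown here, compound 2 `CCS[C@@H]1[C@H](SCC)[C@@H](Cn2cc(-c3ccc(C)cc3)nn2)O[C@H]1n1ccc(=O)[nH]c1=O` gives 19900 nM in a functional assay on HepG2 cells (Homo sapiens) for cytotoxicity, read by MTT assay, with a stated time of 72 h (a lower number here means that less compound is needed, a higher number that more compound is needed for the effect), the highest of the two numbers measured so far. Among the measured compounds shown here, the nearest is compound 1 `CCS[C@@H]1[C@H](SCC)[C@@H](Cn2cc(-c3ccccc3)nn2)O[C@H]1n1ccc(=O)[nH]c1=O`, which in this assay gives 8380 nM; the only measured step is a 2.4-fold higher number from compound 1 to compound 2 (0.38 log units; beyond the scatter). Compound 3 `CCS[C@@H]1[C@H](SCC)[C@@H](Cn2cc(-c3cccs3)nn2)O[C@H]1n1ccc(=O)[nH]c1=O` carries thiophen-2-yl in place of 4-methylphenyl on an aromatic carbon, so the methyl of compound 2 goes as well. Only that single, modest step bears on the change, so a return toward the number of compound 1 is expected rather than any large move. Compound 3 is estimated at 11000 nM, with a range of 4000 nM to 30000 nM. That estimate corresponds to an expected step of a 1.8-fold lower number from compound 2 to compound 3 (0.26 log units; within the scatter).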

Compound 3, half-maximal effective concentration: 91800 nM
For compound 3 the middle estimate is 8.3-fold (0.92 log units) below the measured one, outside the stated range (above it).
By their numbers in this assay, from the lowest: compound 1; then compound 2; then compound 3.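

In this assay this aromatic carbon tolerates a change of ring far less well than the methyl step suggested: thiophen-2-yl in place of 4-methylphenyl gives a 4.6-fold higher number from compound 2 to compound 3 (0.66 log units; beyond the scatter) and thiophen-2-yl in place of phenyl gives an 11-fold higher number from compound 1 to compound 3 (1.04 log units; beyond the scatter) in the same series. Losing the methyl therefore does not describe this change, since compound 1 also lacks it and has the lowest number of the three. No measured data explain the rise.

From the compounds shown here alone, whether the rise is specific to thiophen-2-yl or extends to other five-membered aromatic rings remains open. So does the effect of an amine or a carboxylic acid on the phenyl ring.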